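The source may hold more compounds than are shown below. What is called first, only, known or untested is meant among the compounds shown, and "the series" means these compounds.

Measured compounds and their values in a functional assay on C6 cells (Rattus norvegicus) for cytotoxicity, read by MTT assay, with a stated time of 24 h, tested at 25 ug/mL; a lower number here means a stronger effect, a higher number a weaker effect of the compound at the concentration tested:

Compound 1, `Cc1ccc(-c2cs/c(=N/NC(=O)CSc3nnnn3-c3ccccc3)n2-c2ccccc2)cc1`: 38.8%
Compound 2, `Cc1ccc(-c2cs/c(=N/NC(=O)CSc3nnnn3C)n2-c2ccccc2)cc1`: 60.7%
Compound 3, `COc1ccc(-c2cs/c(=N/NC(=O)CSc3nnc(C)s3)n2-c2ccccc2)cc1`: 42.6%

Among these three numbers, compound 3 stands second highest. Its nearest neighbour is compound 1, whose value lies within the scatter of that of compound 3, so the two cannot be told apart. Its furthest neighbour is compound 2, whose value lies beyond the scatter above that of compound 3. For the measured compounds named here, the only measured step is a number 21.9 percentage points higher from compound 1 to compound 2 (beyond the scatter), and it concerns a different change at a different place in the shared core.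

Compound 4, `Cc1ccc(-c2cs/c(=N/NC(=O)CSc3nnc(C)s3)n2-c2ccccc2)cc1`, differs from compound 3 in one place: methyl in place of methoxy on an aromatic carbon. Going by the values given here, no measured pair shows this change, so nothing here tells how it shifts this assay. Compound 1, which carries the same 4-methylphenyl group, sits within the scatter of compound 3. The expected step is therefore none beyond the scatter, a number 0.4 percentage points higher from compound 3 to compound 4 (within the scatter), and compound 4 is estimated at 43%, with a range from 30% to 58%.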

Compound 4, a percentage reported as activity, at one concentration (the size of the read-out at that concentration, not a potency): 50.1%
Compound 4: the middle estimate sits 7.1 percentage points below what was measured; the range from low to high includes it.
By their numbers in this assay, from the lowest: compounds 1, 3 and 4 (each within the scatter of the next, the first and the last beyond it); then compound 2.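

The swap of 4-methoxyphenyl to 4-methylphenyl can now be read directly, and in this assay it leaves the two compounds indistinguishable (a number 7.5 percentage points higher from compound 3 to compound 4 (within the scatter)). With the 4-methylphenyl group held fixed, the group on the sulfur does matter, though modestly: 5-methyl-1,3,4-thiadiazol-2-yl in place of 1-methyl-1H-tetrazol-5-yl gives one step (a number 10.6 percentage points lower from compound 2 to compound 4 (beyond the scatter)) and in place of 1-phenyl-1H-tetrazol-5-yl gives another, in the opposite direction (a number 11.3 percentage points higher from compound 1 to compound 4 (beyond the scatter)). No measurement is available that explains these steps.

The compounds shown carry only methoxy and methyl on this aromatic carbon, so the effect of an amine, a carboxylic acid or a longer chain there remains open. Also open, as far as these compounds go, is whether the methoxy-to-methyl swap would read the same with either tetrazole group on the sulfur.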